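The source may hold more compounds than are shown below. What is called first, only, known or untested is meant among the compounds shown, and "the series" means these compounds.

Measured so far in a functional assay on Raji cells (Homo sapiens) for cytotoxicity, with a stated time of 72 h; on this read-out higher numbers stand for an effect only at larger amounts of compound and lower numbers for an effect already at smaller amounts:
- compound 1 `C=C[C@@](C)(/C=C/c1ccc(O)c(CO)c1)CCC=C(C)C`: > 26000 nM
- compound 2 `C=C[C@@](C)(/C=C/c1ccc(O)c(/C=C(\C)C(=O)OCC)c1)CCC=C(C)C`: > 26000 nM
- compound 3 `CC(C)=CCC[C@@](C)(/C=C/c1ccccc1)/C=C/c1ccc(O)cc1`: > 26000 nM

Compound 3 gives > 26000 nM, which is a limit of the assay and not a number. The whole set stands at the same place: the limit of > 26000 nM in this assay, at which 3 of the 3 values shown sit.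

Compound 4 `CC(C)=CCC[C@](C)(/C=C/c1ccc(O)cc1)/C=C/c1cccc(F)c1` turns the phenyl of compound 3 into a 3-fluorophenyl: fluoro in place of hydrogen on an aromatic carbon. Going by the values given here, the only measured step between two compounds that differ in one place is a step that the two limits leave unreadable from compound 1 to compound 2. It concerns a different exchange of groups, and its size cannot be read. Among the compounds with values here, no measured step therefore shows what fluoro in place of hydrogen does in this assay, so no step beyond the scatter is expected, in either direction. The expectation rests on compound 3, whose limit is > 26000 nM. Compound 4 will most likely also be reported only as a limit. The estimated step is a step that the limit leaves unreadable from compound 3 to compound 4. For compound 4 the expected value is 30000 nM, with an estimated range of 12000 nM to 60000 nM.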

Compound 4, half-maximal effective concentration: > 26000 nM
Compound 4 was reported as a limit (the forecaster's own chance of this, stated with the estimate: 85%); the middle value does not contradict the limit.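

In this assay, compound 3 and compound 4 are both reported only as limits, so no size can be read for the exchange of hydrogen for fluoro. All the compounds shown sit together: the limit of > 26000 nM in this assay, at which 4 of the 4 values shown sit. They leave open which structural change, if any, would give a readable value here.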